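A few compounds are considered here, and "the series" means these few. Any claim that something is new, unique, unknown or untested is made for them only; others in the source may bear on it.

Values so far in a functional assay on HepG2 cells (Homo sapiens) for antiproliferative activity, read by MTT assay, with a stated time of 72 h (a lower number here means a stronger inhibitor, a higher number a weaker inhibitor), as working notes
- compound 1 `O=C(N/N=C/c1ccc(O)cc1)Nc1ccc(Oc2ccnc3[nH]ccc23)cc1` gives 32200 nM
- compound 2 `CCN(CC)CCCn1cccc1/C=N/NC(=O)Nc1ccc(Oc2ccnc3[nH]ccc23)c(F)c1` gives 2140 nM
- compound 3 `O=C(N/N=C/c1cccn1CCCN1CCCC1)Nc1ccc(Oc2ccnc3[nH]ccc23)c(F)c1` has no value yet

Compound 2 holds the lower of the two numbers, and the gap up to compound 1 lies beyond the usual scatter. Compound 1 and compound 2 differ in more than one place, so their gap gives no direct reading on the change now in question.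

Going on to compound 3, the change is confined to the end of the chain: pyrrolidin-1-yl in place of diethylamino on a saturated chain carbon, three bonds along the chain from an aromatic nitrogen. Pyrrolidin-1-yl stands in place of diethylamino on a saturated chain carbon, three bonds along the chain from an aromatic nitrogen, so 3-(diethylamino)propyl becomes 3-(pyrrolidin-1-yl)propyl.

Going by the values given here, no measured pair shows this change. With the value of compound 2 at 2140 nM as the only anchor, no step beyond the scatter is expected in this assay, and no direction is favoured. The estimated change is a 1.1-fold lower number from compound 2 to compound 3 (0.03 log units; within the scatter) in size. For compound 3 the estimated value is 2000 nM within an expected range from 800 nM to 5000 nM in this read-out.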

Compound 3, half-maximal inhibitory concentration: 3500 nM
Beside the measured number, compound 3's estimate is 1.8-fold (0.24 log units) below it; measured number inside the range.
By their numbers in this assay, from the lowest: compounds 2 and 3 (each within the scatter of the next); then compound 1.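

In this assay, going by these compounds alone, the one pair that differs in a single place gives a 1.6-fold higher number from compound 2 to compound 3 (0.21 log units; within the scatter), so compound 2 and compound 3 cannot be told apart in this read-out. At the end of the chain, on a saturated chain carbon, three bonds along the chain from an aromatic nitrogen, this pair therefore gives no sign that the open diethylamino group and the ring of pyrrolidin-1-yl read differently, although the two groups match in heavy atoms and the ring is the only difference counted between them. Nothing available on these compounds offers an explanation of this result.

Still open, on these data alone, is whether this tolerance extends to other ends of the chain, such as a piperidine, a morpholine, an N-methylpiperazine or a terminal carboxylic acid, or to a chain end without any amine. Also open, as far as these compounds go, is whether the same pair of end groups would read alike on a shorter 2-carbon ethyl linker or a longer butyl linker, and whether the chain itself contributes to the values in this assay.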